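Extending compound 3 with a benzylsulfanyl group

A few compounds are considered here, and "the series" means these few. Any claim that something is new, unique, unknown or untested is made for them only; others in the source may bear on it.

Three compounds have numbers in an assay on isolated protein (Sus scrofa) for inhibition of 2-Hydroxyacid oxidase 1 (Homo sapiens); a lower number here means a stronger inhibitor, a higher number a weaker inhibitor. Compound 1 `CC1=C(/C=C/C(=O)CC(=O)C(=O)O)C(C)(C)CCC1` gives 1400 nM in this assay. Compound 2 `O=C(/C=C/c1ccccc1)CC(=O)C(=O)O` gives 19000 nM in this assay. Compound 3 `O=C(O)C(=O)CC(=O)c1ccc(-c2ccccc2)cc1` gives 1100 nM in this assay, the lowest of the three numbers; its gap to compound 1 lies within the scatter of repeated measurements, so no order between these two can be read, while its gap to compound 2 lies beyond the scatter. Going by the values given here, compound 2 and compound 3 share the keto-acid chain and differ in the aryl part, but no single-point step between them is counted here.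

Compound 4 `O=C(O)C(=O)CC(=O)c1ccc(-c2ccc(SCc3ccccc3)cc2)cc1` has not yet been measured in this assay. It differs from compound 3 by benzylsulfanyl in place of hydrogen on an aromatic carbon. No measured step covers a change of this kind in the series. A modest move toward a lower number is expected, with the step from compound 3 to compound 4 estimated at a 2.8-fold lower number from compound 3 to compound 4 (0.44 log units; beyond the scatter). Compound 4 is accordingly expected to give about 400 nM in this assay, with a range from 100 nM to 1500 nM.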

Compound 4, half-maximal inhibitory concentration: 400 nM
For compound 4 middle estimate and measured number coincide at the digits printed; the range from low to high includes it.
By their numbers in this assay, from the lowest: compound 4; then compounds 3 and 1 (each within the scatter of the next); then compound 2.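

In this assay, going by these compounds alone, the change of benzylsulfanyl in place of hydrogen on an aromatic carbon gives a 2.8-fold lower number from compound 3 to compound 4 (0.44 log units; beyond the scatter) and is the first single-place step. This position, para to a large group, therefore accepts a substituent of 8 heavy atoms, including a further six-membered aromatic ring, and the number falls rather than rises. No measurement shown accounts for the size of this step.

The compounds shown do not separate the contributions of the sulfur atom and the terminal phenyl ring, so the part of benzylsulfanyl that carries the step remains open; methylsulfanyl, benzyloxy or a plain benzyl group at this position would address that. Also open, from the compounds shown here alone, is whether a longer chain between the sulfur and the ring, or an amine or carboxylic acid on that ring, would move the number further.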